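The source may report more compounds than this note shows. Statements on the series, on what has been measured and on what is new or still open speak of the compounds shown alone.

Working notes on the indole series. Compound 1 `Fc1ccc(-c2[nH]c3cc(F)ccc3c2Cn2ccnc2)cc1` is the reference point: in an assay on isolated protein for inhibition of Aromatase (Homo sapiens), read by ELISA, using NADPH, with a stated time of 24 h (a higher number here means a weaker inhibitor, a lower number a stronger inhibitor), compound 1 gives 51.2 nM. Compound 2 `Fc1ccc2c(Cn3ccnc3)c(-c3ccc(Cl)cc3)[nH]c2c1` differs by chloro in place of fluoro on an aromatic carbon, and in this assay compound 2 gives 82.9 nM, so that the change made a 1.6-fold higher number from compound 1 to compound 2 (0.21 log units; within the scatter). Compound 3 `Fc1ccc(-c2[nH]c3cc(Cl)ccc3c2Cn2cncn2)cc1` carries a different core; how its core differs from that of compound 1 is not broken down here. In this assay compound 3 gives 96.9 nM, a value within the scatter of compound 2 and of compound 1.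

Compound 4 `Clc1ccc(-c2[nH]c3cc(Cl)ccc3c2Cn2cncn2)cc1` is not yet measured. It repeats the same change on the core of compound 3, (chloro in place of fluoro on an aromatic carbon), at a place described in the same words as before. The step from compound 3 to compound 4 in this assay is expected to be a 1.6-fold higher number from compound 3 to compound 4 (0.20 log units; within the scatter), resting on the earlier step of a 1.6-fold higher number from compound 1 to compound 2 (0.21 log units; within the scatter). Compound 4 is therefore estimated at 155 nM, with a range from 75 nM to 320 nM.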

Compound 4, half-maximal inhibitory concentration: 208 nM
Estimate against measurement, compound 4: 1.3-fold (0.13 log units) below, and the stated range covers the measured number.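

In this assay, going from 4-fluorophenyl to 4-chlorophenyl on the core of compound 3 gives a 2.1-fold higher number from compound 3 to compound 4 (0.33 log units; beyond the scatter), and the two steps do not differ beyond what repeated measurement allows: the same change on two cores in this assay, a 1.6-fold higher number (0.21 log units; within the scatter) from compound 1 to compound 2 and a 2.1-fold higher number (0.33 log units; beyond the scatter) from compound 3 to compound 4, 1.3-fold (0.12 log units) apart, within the scatter of two such steps. The change therefore carries over between these two cores with a similar size and the same direction, even though only the newer step lies beyond the scatter. Among the compounds shown here, with only two pairs, this does not show that the step would hold on any further core, and it gives no reason for the step.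

On these data alone, only fluoro and chloro appear at this place, so the outcome with a bromo, a methoxy, an amine or a carboxylic acid remains open.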